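Ester to amide at the chain end: expected microsomal half-life

A few compounds are considered here, and "the series" means these few. Any claim that something is new, unique, unknown or untested is made for them only; others in the source may bear on it.

Measured compounds:
compound 1, `CCOc1cc(NC(=O)C2(NC(=O)c3ccc4c(C5CCCC5)c(-c5ncc(Cl)cn5)n(C)c4c3)CCC2)ccc1/C=C/C(=O)OCOP(=O)(O)O`, 0.167 h
compound 2, `CCOc1cc(NC(=O)C2(NC(=O)c3ccc4c(C5CCCC5)c(-c5ncc(Cl)cn5)n(C)c4c3)CCC2)ccc1/C=C/C(=O)OCC(=O)OCc1ccc(Cl)cc1`, 5.62 h

In an ADME assay (liver) for pharmacokinetics, with Liver microsome (Homo sapiens) as the target, using microsomes (a higher number here means that the compound lasts longer, a lower number that the compound disappears faster), compound 2 stands highest of the two numbers; its nearest neighbour is compound 1, and the step of a 34-fold higher number from compound 1 to compound 2 (1.53 log units; beyond the scatter) was large. Compound 3, `CCCN(C)C(=O)COC(=O)/C=C/c1ccc(NC(=O)C2(NC(=O)c3ccc4c(C5CCCC5)c(-c5ncc(Cl)cn5)n(C)c4c3)CCC2)cc1OCC`, differs from compound 2 by methyl(propyl)amino in place of (4-chlorobenzyl)oxy on a carbonyl carbon. For the measured compounds named here, no measured step touches this kind of change, so the only guide is that the prior change at the same chain end moved the number strongly. The step of a 1.9-fold lower number from compound 2 to compound 3 (0.27 log units; within the scatter) is therefore expected to be modest, in either direction within the scatter. Compound 3 is estimated at 3 h, in the range 0.8 h to 10 h.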

Compound 3, half-life: 0.317 h
Beside the measured number, compound 3's estimate is 9.5-fold (0.98 log units) above it; measured number outside the range, below it.
By their numbers in this assay, from the lowest: compounds 1 and 3 (each within the scatter of the next); then compound 2.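

In this assay, exchanging the group on this carbonyl carbon, with methyl(propyl)amino in place of (4-chlorobenzyl)oxy, gives an 18-fold lower number from compound 2 to compound 3 (1.25 log units; beyond the scatter), so the chain end can change the number strongly even when the saturated chain carbon and carbonyl stay the same. The other new step, a 1.9-fold higher number from compound 1 to compound 3 (0.28 log units; within the scatter), leaves compound 2 alone in standing apart from both other compounds. Nothing available explains this difference.

The compounds shown leave open whether the aromatic ring, the chlorine or the oxygen of (4-chlorobenzyl)oxy matters most. A benzyloxy or benzylamino group on the same carbonyl carbon could separate these.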